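The source may report more compounds than this note shows. Statements on the series, on what has been measured and on what is new or still open speak of the compounds shown alone.

Measured so far:
Compound 1 `N#Cc1ccc(N[C@@H]2CN[C@H](C(=O)N3CCSC3)C2)cc1` gives 33.6 nM in an assay on a cell-free system (plasma) for inhibition of Dipeptidyl peptidase 4 (Rattus norvegicus), read by fluorescence; on this read-out lower numbers stand for stronger inhibition and higher numbers for weaker inhibition.
Compound 2 `O=C([C@@H]1C[C@H](NCc2ccccc2)CN1)N1CCSC1` gives 171 nM in this assay.

Compound 2 stands at the higher of the two numbers, and its gap to compound 1 lies beyond the scatter of repeated measurements. For the measured compounds named here, the two compounds differ in more than one place, so no single step between them can be read off. Compound 3 `N#Cc1ccc(CN[C@@H]2CN[C@H](C(=O)N3CCSC3)C2)cc1` has not yet been measured in this assay. It arises from compound 2 by a single change: cyano in place of hydrogen on an aromatic carbon. Going by the values given here, with no directly comparable step between measured compounds, the size of this change can only be guessed. The lower number seen for compound 1, the only compound shown that carries a cyano group, gives a weak hint that the number for compound 3 may drop. The expected step from compound 2 to compound 3 is therefore a 2.0-fold lower number from compound 2 to compound 3 (0.30 log units; within the scatter), a modest lowering. Compound 3 is estimated at 85 nM, within a range from 30 nM to 250 nM.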

Compound 3, half-maximal inhibitory concentration: 34.3 nM
Compound 3: middle estimate off by 2.5-fold (0.39 log units), on the high side, and the stated range covers the measured number.
By their numbers in this assay, from the lowest: compounds 1 and 3 (each within the scatter of the next); then compound 2.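

In this assay, for the compounds shown here, the first step that can be read at this ring position is large enough to count: putting cyano in place of hydrogen on the aromatic carbon para to a large group gives a 5.0-fold lower number from compound 2 to compound 3 (0.70 log units; beyond the scatter). The earlier compounds shown here offered only a weak hint of this, since they differed in more than one place, whereas here a single change of 2 heavy atoms separates the pair and brings compound 3 within the scatter of compound 1. The data shown offer no measurement that explains why the number falls.

Going by these compounds, only hydrogen and cyano appear at this carbon, so how a chlorine atom, a methoxy group or a carboxylic acid would compare remains open. Whether cyano would give a similar step at another carbon of the ring is also unknown.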